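Swapping the aryl group on a thioether-linked nucleoside

The source may report more compounds than this note shows. Statements on the series, on what has been measured and on what is new or still open speak of the compounds shown alone.

Of the compounds shown here, two have been measured in an assay on isolated protein for inhibition of Equilibrative nucleoside transporter 1 (Homo sapiens); a lower number here means a stronger inhibitor, a higher number a weaker inhibitor. Compound 1 `N#Cc1ccccc1CSc1ncnc2c1ncn2[C@@H]1O[C@H](CO)[C@@H](O)[C@H]1O` gives 38.9 nM. Compound 2 `O=[N+]([O-])c1cccc(CSc2ncnc3c2ncn3[C@@H]2O[C@H](CO)[C@@H](O)[C@H]2O)c1` gives 1.78 nM, the lowest of the two numbers, and the step of a 22-fold lower number from compound 1 to compound 2 (1.34 log units; beyond the scatter) shows how far the two lie apart. Compound 3 `OC[C@H]1O[C@@H](n2cnc3c(SCc4ccc(Cl)cc4Cl)ncnc32)[C@H](O)[C@@H]1O` has not been measured; it differs from compound 2 in one place: 2,4-dichlorophenyl in place of 3-nitrophenyl on a saturated chain carbon bound to a sulfur. Going by the values given here, the only step that bears on this position is the one from compound 1 to compound 2, and it was large, which shows that the aryl group on the saturated chain carbon bound to a sulfur can move the number a long way. Among the compounds with values here, no step with a halogen-bearing aryl group exists here, so the direction is uncertain. For compound 3 a modest loss is expected, a 2.8-fold higher number from compound 2 to compound 3 (0.45 log units; beyond the scatter), giving an estimated 5 nM with a range from 1 nM to 25 nM.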

Compound 3, inhibition constant: 4.37 nM
For compound 3 the middle estimate is 1.1-fold (0.06 log units) above the measured one; the measured number falls inside the stated range.
By their numbers in this assay, from the lowest: compound 2; then compound 3; then compound 1.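

A halogen-bearing aryl group now has a number at this position, on a saturated chain carbon bound to a sulfur: in this assay there is a 2.5-fold higher number from compound 2 to compound 3 (0.39 log units; beyond the scatter), a modest loss. Against the other aryl group the change is far more favourable, with an 8.9-fold lower number from compound 1 to compound 3 (0.95 log units; beyond the scatter), so a strong result here does not depend on the nitro group, and 2,4-dichlorophenyl, with 0 hydrogen-bond acceptors where 3-nitrophenyl has 2, still gives a low number. Nothing given here accounts for the differences among these aryl groups.

The three aryl groups differ both in their substituents and in where those sit, so the two influences cannot be separated. From the compounds shown here alone, how a plain phenyl group, a phenyl ring carrying an amine, or a longer chain between the sulfur and the ring would compare remains open.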